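Swapping a nitro group for methyl on a tolerated scaffold

This account rests on a few compounds, and the source may have more. Where it says the series, first, only, none or still open, it means among the compounds named here.

Of the compounds shown here, three have so far been tested in an ADME assay on RAW264.7 cells (Mus musculus) for cytotoxicity, read by MTT assay, with a stated time of 48 h; a lower number here means that less compound is tolerated, a higher number that more compound is tolerated. Compound 1, `C#Cc1ccc(-c2noc(NC3CCCCC3)n2)cc1`, gives 19.8 ug/mL. Compound 3, `CC(=O)OC[C@H]1O[C@H](OC[C@H](Cn2cc(-c3ccc(-c4noc(NC5CCCCC5)n4)cc3)nn2)OC(C)=O)C=C[C@@H]1OC(C)=O`, gives 16.3 ug/mL. Compound 2, `CC(=O)OC[C@H]1O[C@H](OC[C@@H](Cn2cc(CN(c3nc(-c4ccc([N+](=O)[O-])cc4)no3)C3CCCCC3)nn2)OC(C)=O)C=C[C@@H]1OC(C)=O`, gives 64.1 ug/mL, the highest of the three numbers, and its gap to each of the other two lies beyond the usual scatter, so among these three it is the one whose cells tolerate the most material.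

Compound 4, `CC(=O)OC[C@H]1O[C@H](OC[C@@H](Cn2cc(CN(c3nc(-c4ccc(C)cc4)no3)C3CCCCC3)nn2)OC(C)=O)C=C[C@@H]1OC(C)=O`, is the untested partner of compound 2. The difference between them is methyl in place of nitro on an aromatic carbon of the phenyl ring that hangs from the shared core. Going by the values given here, no measured pair in this set shows this same swap, so nothing here tells how large a step it brings, and the expectation below rests only on the standing of compound 2.

In this assay compound 4 is expected to give about 45 ug/mL, with a plausible range from 20 ug/mL to 100 ug/mL. That estimate means a step of a 1.4-fold lower number from compound 2 to compound 4 (0.15 log units; within the scatter), expected to be small, downward if anything, and possibly not beyond the scatter.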

Compound 4, half-maximal cytotoxic concentration: 45.3 ug/mL
Compound 4: the middle estimate sits 1.0-fold (0.00 log units) below what was measured; the range from low to high includes it.
By their numbers in this assay, from the lowest: compounds 3 and 1 (each within the scatter of the next); then compounds 4 and 2 (each within the scatter of the next).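

Going by these compounds alone, this is the first pair in the set that differs in one place only, so the swap of nitro for methyl can now be sized: in this assay it amounts to a 1.4-fold lower number from compound 2 to compound 4 (0.15 log units; within the scatter), and that step lies within the scatter. On an aromatic carbon para to a large group, the 3 heavy atoms and 2 hydrogen-bond acceptors of nitro give way to the 1 heavy atom and no acceptors of methyl, yet the two numbers cannot be told apart, so on this scaffold the higher tolerated level does not depend on the nitro group being present. Nothing available here explains why the two groups read alike.

Within the data shown here, this single pair covers only two groups at this position, so it remains open whether an amine, a carboxylic acid or a longer chain such as butyl would also stay within the scatter. It also cannot show whether the same swap would give so small a step on a different scaffold.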